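The source may hold more compounds than are shown below. What is called first, only, known or untested is meant among the compounds shown, and "the series" means these compounds.

Measured compounds:
- compound 1, `Cn1ncc(Cl)c1-c1cc(C(=O)N[C@@H]2CN[C@H](CCn3cncn3)C[C@H]2c2ccc(Cl)c(Cl)c2)oc1Cl`: 60 nM
- compound 2, `Cn1ncc(Cl)c1-c1cc(C(=O)N[C@@H]2CN[C@H](CCO)C[C@H]2c2ccc(F)c(F)c2)oc1Cl`: 60 nM
- compound 3, `CC(=O)OCC[C@@H]1C[C@@H](c2ccc(F)c(F)c2)[C@H](NC(=O)c2cc(-c3c(Cl)cnn3C)c(Cl)o2)CN1`: "not determined" (no result reported)

In a functional assay on LNCaP cells (Homo sapiens) for antiproliferative activity (a lower number here means a stronger inhibitor, a higher number a weaker inhibitor), compound 1 gives 60 nM. Compound 2 stands level with it at the digits shown, since compound 2 gives 60 nM, a difference within the scatter. Compound 3 carries no number in this assay, so it adds nothing to the comparison.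

The step to compound 4, `Cn1ncc(Cl)c1-c1cc(C(=O)N[C@@H]2CN[C@H](CCN3CCC(O)CC3)C[C@H]2c2ccc(Cl)c(Cl)c2)oc1Cl`, is this: 4-hydroxypiperidin-1-yl in place of 1H-1,2,4-triazol-1-yl on a saturated chain carbon, two bonds along the chain from a saturated ring carbon. Both neighbours of compound 1 with a changed substituent on this chain sit at the same value, so the change is expected to move the result little, if at all, beyond the scatter. Compound 4 is therefore estimated at 60 nM, within 25 nM to 150 nM, a step of no change at the digits printed from compound 1 to compound 4 (within the scatter) expected from compound 1.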

Compound 4, half-maximal inhibitory concentration: 1140 nM
Beside the measured number, compound 4's estimate is 19-fold (1.28 log units) below it; measured number outside the range, above it.
By their numbers in this assay, from the lowest: compounds 1 and 2 (each within the scatter of the next); then compound 4.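

In this assay the group on this chain proves not to be interchangeable: 4-hydroxypiperidin-1-yl in place of 1H-1,2,4-triazol-1-yl gives a 19-fold higher number from compound 1 to compound 4 (1.28 log units; beyond the scatter) on the same core. This shows that the result responds strongly to the substituent on a saturated chain carbon, two bonds along the chain from a saturated ring carbon. No measurement given here bears on the reason for this step. On these data alone, what a plain piperidin-1-yl or a morpholin-4-yl on the same chain would give remains open, and with it whether the step follows the hydroxyl or the ring itself.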